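The source may hold more compounds than are shown below. What is called first, only, known or untested is meant among the compounds shown, and "the series" means these compounds.

For the measured compounds named here, compound 1 `O=S(=O)(c1ccc2cccnc2c1)n1cc(C2=CCNCC2)c2ccccc21` stands second highest of the three numbers known in an assay on HEK293 cells for displacement of a labelled ligand from 5-hydroxytryptamine receptor 6 (Homo sapiens), read by scintillation counting (on this read-out higher numbers stand for weaker inhibition and lower numbers for stronger inhibition), where compound 1 gives 7 nM; compound 2 `O=S(=O)(c1ccc2cccnc2c1)n1cc(C2=CCNCC2)c2cc(Cl)ccc21` gives 9 nM and compound 3 `COc1ccc2c(c1)c(C1=CCNCC1)cn2S(=O)(=O)c1ccc2cccnc2c1` gives 2 nM. Compound 4 `O=S(=O)(c1ccc2cccnc2c1)n1cc(C2=CCNCC2)c2ccc(Cl)cc21` differs from compound 1 by chloro in place of hydrogen on an aromatic carbon. The step that bears most directly on it is a 1.3-fold higher number from compound 1 to compound 2 (0.11 log units; within the scatter), where chloro likewise enters on the carbon-only ring of the shared core; the methoxy step a 3.5-fold lower number from compound 1 to compound 3 (0.54 log units; beyond the scatter) concerns a different group and says less here. Compound 4 is therefore expected to stay within the scatter of compound 1, with an expected step of a 1.1-fold higher number from compound 1 to compound 4 (0.06 log units; within the scatter). The estimate for compound 4 in this assay is 8 nM, with a range from 4 nM to 16 nM.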

Compound 4, inhibition constant: 22 nM
For compound 4 the middle estimate is 2.8-fold (0.44 log units) below the measured one; measured number above the stated range.
By their numbers in this assay, from the lowest: compound 3; then compounds 1 and 2 (each within the scatter of the next); then compound 4.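

In this assay, chloro on this carbon of the six-membered aromatic ring of carbon only does not behave as a neutral change: it gives a 3.1-fold higher number from compound 1 to compound 4 (0.50 log units; beyond the scatter). Chloro elsewhere on the core gives a 1.3-fold higher number from compound 1 to compound 2 (0.11 log units; within the scatter), so among these compounds the outcome of this change depends on where the chloro sits. Nothing available here accounts for that difference.

From the compounds shown here alone, whether methoxy on this same carbon would lower the number, as it does in compound 3 at its own place, remains open. So does what fluoro, an amine or a carboxylic acid would give there.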